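Methoxy addition on the shared core: expected cytotoxicity readout

The source may report more compounds than this note shows. Statements on the series, on what has been measured and on what is new or still open speak of the compounds shown alone.

Of the compounds shown here, three on the shared core have been measured in a functional assay on PC-3 cells (Homo sapiens) for cytotoxicity, read by sulforhodamine B assay, with a stated time of 48 h, tested at 0.1 uM; on this read-out higher numbers stand for a weaker effect at the one concentration tested and lower numbers for a stronger effect. Compound 1 `COc1cc(-c2cc(/C=C/C(=O)c3ccc(N)cc3)[nH]n2)cc(OC)c1OC` gives 94% in this assay. Compound 2 `COc1ccc(-c2cc(/C=C/C(=O)c3ccc(OC)c(OC)c3)[nH]n2)cc1` gives 91% in this assay. Compound 3 `COc1ccc(-c2cc(/C=C/C(=O)c3cc(OC)c(OC)c(OC)c3)[nH]n2)cc1OC` gives 93% in this assay. Compound 3 stands second of the three numbers; its nearest neighbour is compound 1 and its furthest is compound 2, yet both of those values lie within the scatter of the value of compound 3, so the three compounds cannot be told apart on these data. At the single concentration tested all three leave most of the cells growing.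

Going by the values given here, no pair of measured compounds differs in one place only, so no step within the measured set is available to guide the next compound. Compound 4 `COc1cc(C(=O)/C=C/c2cc(-c3cc(OC)c(OC)c(OC)c3)n[nH]2)cc(OC)c1OC` differs from compound 3 by methoxy in place of hydrogen on an aromatic carbon. The new group sits ortho to a methoxy group, meta to a large group and meta to a methoxy group.

Given that compounds 1, 2 and 3 all sit within the scatter of one another despite carrying methoxy groups in different numbers and places, the step from compound 3 to compound 4 is expected to be a number 1 percentage points lower from compound 3 to compound 4 (within the scatter), that is, none beyond the scatter. Compound 4 is estimated to give 92% in this assay, with a range from 80% to 100%.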

Compound 4, a percentage reported as activity, at one concentration (the size of the read-out at that concentration, not a potency): 92%
Beside the measured number, compound 4's estimate shows no gap at the digits printed; the range from low to high includes it.
By their numbers in this assay, from the lowest: compounds 2, 4, 3 and 1 (each within the scatter of the next).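

Methoxy in place of hydrogen on an aromatic carbon, ortho to a methoxy group, meta to a large group and meta to a methoxy group, gives the only single-place step in the series so far in this assay, namely a number 1 percentage points lower from compound 3 to compound 4 (within the scatter), so this change can now be read directly rather than inferred from compounds that differ in several places. At this position and at the one concentration tested, the added methoxy does not separate compound 3 from compound 4, and compound 4 gives 92%, which still leaves most of the cells growing. Nothing available bears on the reason for this result.

Going by these compounds, whether a carboxylic acid, a chloro group or an ethoxy group at the same position would give a step beyond the scatter remains open. Also open, on these data alone, is whether this reading would hold at other concentrations or at other positions on the shared core, since a single step on one ring says nothing about either.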